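This account rests on a few compounds, and the source may have more. Where it says the series, first, only, none or still open, it means among the compounds named here.

Compound 1, with the structure `CN(C)c1c(C#N)c2c(N)ncnc2n1C`, is the weaker of the two compounds for which a number exists: in an assay on isolated protein for inhibition of Leucine-rich repeat serine/threonine-protein kinase 2 (Homo sapiens), read by TR-FRET and LanthaScreen, with stated times of 50 min and 30 min, in the presence of a further agent that is not named here (on this read-out higher numbers stand for weaker inhibition and lower numbers for stronger inhibition), compound 1 gives 4620 nM. Within the data shown here, the only other measured compound is compound 2, with the structure `C[C@@H]1CCCN1c1c(C#N)c2c(N)nc(Nc3cn(C)nc3Cl)nc2n1C`, which in this assay gives 34 nM; compound 2 differs from compound 1 in more than one place, so the gap between the two numbers cannot be assigned to any single change. Compound 3, with the structure `C[C@H]1CCCN1c1c(C#N)c2c(N)ncnc2n1C`, is not yet measured. Its difference from compound 1 is 2-methylpyrrolidin-1-yl in place of dimethylamino on an aromatic carbon. Among the measured compounds shown here, no measured pair isolates this exchange. Since compound 2 carries the same kind of ring and gives 34 nM, some gain beyond the scatter is expected from the step from compound 1 to compound 3, but a smaller one than the full gap, and the estimate is a 3.1-fold lower number from compound 1 to compound 3 (0.49 log units; beyond the scatter). For compound 3 the expected value in this assay is 1500 nM, with a range from 400 nM to 6000 nM.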

Compound 3, half-maximal inhibitory concentration: 5660 nM
Compound 3: middle estimate off by 3.8-fold (0.58 log units), on the low side, within the range that was stated.
By their numbers in this assay, from the lowest: compound 2; then compounds 1 and 3 (each within the scatter of the next).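

In this assay, 2-methylpyrrolidin-1-yl in place of dimethylamino on this aromatic carbon, next to the ring nitrogen, gives a 1.2-fold higher number from compound 1 to compound 3 (0.09 log units; within the scatter) and so leaves the number within the scatter. On the core of compound 1, this position therefore accepts the ring with its added heavy atoms and defined stereocentre, with no measurable difference in inhibition in this assay between the two groups. The exchange alone also does not bring the core to the level of compound 2 at 34 nM, so the low number of compound 2 must involve something beyond this exchange, and no data shown here give a reason for the flat step.

What the compounds shown leave open is whether an unsubstituted pyrrolidin-1-yl, a morpholin-4-yl or the mirror-image form of 2-methylpyrrolidin-1-yl at this carbon would also stay within the scatter of compound 1. Among these compounds, they also leave open whether the 2-methylpyrrolidin-1-yl group matters at all once the further substituent of compound 2 is present, since no pair here separates the two changes.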